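Series notes: a third substituent at one aromatic carbon

The compounds below may be only part of what the source reports. "The series", "measured", "known", "first", "only" and "open" are said of these compounds alone.

Measured so far:
compound 1 `COCOc1cc(=O)oc2cc(OCc3cccc(Cl)c3)ccc12`: 23%
compound 2 `CCNC(=O)Nc1cc(=O)oc2cc(OCc3cccc(Cl)c3)ccc12`: 0%

In an assay on isolated protein (strain Sprague-Dawley) for inhibition of Amine oxidase [flavin-containing] A (Rattus norvegicus), read by spectrophotometry, with a stated time of 5 min, tested at 10 uM (on this read-out lower numbers stand for less inhibition and higher numbers for more inhibition at the one concentration tested (going by the name of the read-out)), compound 1 gives 23%, while compound 2 gives 0%. Compound 2 stands lowest of the two, set apart by the step of a number 23 percentage points lower from compound 1 to compound 2 (beyond the scatter). Compound 3 `O=C(O)c1cc(=O)oc2cc(OCc3cccc(Cl)c3)ccc12` differs from compound 2 by carboxy in place of (ethylcarbamoyl)amino on an aromatic carbon. Among the compounds with values here, only the step from compound 1 to compound 2 concerns this position, and it was modest; a different group entering now gives no firm guide. A small step is expected, a number 8 percentage points higher from compound 2 to compound 3 (within the scatter), no larger than the earlier one. Compound 3 is expected at 8%, with a range from 0% to 25%.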

Compound 3, a percentage reported as inhibition, at one concentration (the size of the read-out at that concentration, not a potency): 0%
Beside the measured number, compound 3's estimate is 8 percentage points above it; the measured number falls inside the stated range.
By their numbers in this assay, from the lowest: compounds 2 and 3 (each within the scatter of the next); then compound 1.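

In this assay, carboxy and (ethylcarbamoyl)amino on this aromatic carbon, opposite the ring oxygen, read alike, with no change at the digits printed from compound 2 to compound 3 (within the scatter), despite their different heavy-atom counts. Of the three groups, methoxymethoxy alone stands apart: a number 23 percentage points lower from compound 1 to compound 3 (beyond the scatter), so a second replacement for it also gives a lower number. Nothing measured here bears on why these groups read as they do. From the compounds shown here alone, whether an amine, a methoxy group or a longer alkoxy chain on this carbon would match or exceed methoxymethoxy remains open. Also open is which part of methoxymethoxy accounts for its higher number.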